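The source may hold more compounds than are shown below. What is called first, only, known or untested is meant among the compounds shown, and "the series" means these compounds.

Compounds measured in an assay on isolated protein for inhibition of histone deacetylase 8 (Homo sapiens), read by mobility shift assay; a higher number here means a weaker inhibitor, a lower number a stronger inhibitor:
compound 1 `O=C(NO)c1ccc(CN(Cc2ccccc2)S(=O)(=O)c2c(F)c(F)c(F)c(F)c2F)cc1` gives 150 nM;
compound 2 `CC(C)(C)c1ccc(CN(Cc2ccc(C(=O)NO)cc2)S(=O)(=O)c2c(F)c(F)c(F)c(F)c2F)cc1` gives 68 nM.

Compound 2 stands at the lowest of the two numbers, with compound 1 next, separated by the step of a 2.2-fold lower number from compound 1 to compound 2 (0.34 log units; beyond the scatter). Compound 3 `O=C(NO)c1ccc(CN(Cc2ccncc2)S(=O)(=O)c2c(F)c(F)c(F)c(F)c2F)cc1` introduces the change (pyridin-4-yl in place of 4-(tert-butyl)phenyl on a saturated chain carbon bound to a sulfonamide nitrogen). Within the data shown here, the only step that bears on it is the one from compound 1 to compound 2, which removed the same tert-butyl; no measured pair speaks to exchanging the phenyl for pyridin-4-yl. Compound 3 is therefore expected to move back toward compound 1, by a 2.9-fold higher number from compound 2 to compound 3 (0.47 log units; beyond the scatter), giving an estimate for compound 3 of 200 nM, within 80 nM to 500 nM.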

Compound 3, half-maximal inhibitory concentration: > 1000 nM
Compound 3 gave a limit, no number; the forecaster's own chance of this, stated with the estimate: 3%; middle value at least 5.0-fold (0.69 log units) away from the limit.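

Compound 3 stands at a limit of the assay, not at a number: the limit of > 1000 nM in this assay, at which 1 of the 3 values shown sits. Even so, the step of an at least 6.6-fold higher number from compound 1 to compound 3 (0.82 log units; beyond the scatter) shows that this position responds to the ring itself, pyridin-4-yl in place of phenyl, and not only to the tert-butyl changed in the earlier pair. From the compounds shown here alone, the step of an at least 14-fold higher number from compound 2 to compound 3 (1.16 log units; beyond the scatter) is large, and its full size remains unknown.

Going by these compounds, it remains open whether the loss follows the ring nitrogen as such or its location, which pyridin-3-yl or pyridin-2-yl would test. On these data alone, whether 4-methoxyphenyl or 4-chlorophenyl would match 4-(tert-butyl)phenyl also remains open.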